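This account rests on a few compounds, and the source may have more. Where it says the series, first, only, none or still open, it means among the compounds named here.

Three compounds of the series share the core of compound 1 `CNC(=O)COc1cc(=O)oc2cc(OCc3cccc(Cl)c3)ccc12` and differ only in the group on one aromatic carbon. In an assay on isolated protein (strain Sprague-Dawley) for inhibition of Amine oxidase [flavin-containing] A (Rattus norvegicus), read by spectrophotometry, with a stated time of 5 min, tested at 10 uM (a higher number here means more inhibition at the concentration tested (going by the name of the read-out), a lower number less inhibition), compound 1 gives 11%. Compound 2 `O=C(COc1cc(=O)oc2cc(OCc3cccc(Cl)c3)ccc12)N1CCCCC1`, with piperidin-1-yl in place of methylamino on the carbonyl carbon, gives in this assay 9%; the step of a number 2 percentage points lower from compound 1 to compound 2 (within the scatter) is within the scatter, so these two are not ordered. Compound 3 `N#Cc1cc(=O)oc2cc(OCc3cccc(Cl)c3)ccc12` carries cyano in place of those groups and gives 23% in this assay, the highest of the three numbers; the steps of a number 12 percentage points higher from compound 1 to compound 3 (beyond the scatter) and a number 14 percentage points higher from compound 2 to compound 3 (beyond the scatter) both lie beyond the scatter, though both are modest.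

Compound 4 `NC(=O)c1cc(=O)oc2cc(OCc3cccc(Cl)c3)ccc12` is not yet measured. Its change from compound 3 is carbamoyl in place of cyano on an aromatic carbon. The two steps that bear on it, from compound 1 and from compound 2 to compound 3, both show that cyano in place of a group carrying a carbonyl raised inhibition modestly; the reverse, bringing a carbonyl back, has therefore tended toward lower numbers. Carbamoyl is a closer relative of cyano than either group that left in those steps, so no step as large as those is expected. For compound 4 the expected step is a number 8 percentage points lower from compound 3 to compound 4 (within the scatter), within the scatter. Compound 4 is therefore estimated at 15%, with a range from 4% to 27%.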

Compound 4, a percentage reported as inhibition, at one concentration (the size of the read-out at that concentration, not a potency): 14%
Estimate against measurement, compound 4: 1 percentage points above; low and high end bracket the measured number.
By their numbers in this assay, from the lowest: compounds 2, 1, 4 and 3 (each within the scatter of the next, the first and the last beyond it).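

In this assay, carbamoyl opposite the ring oxygen cannot be told apart from cyano, a number 9 percentage points lower from compound 3 to compound 4 (within the scatter), so the added hydrogen-bond donor and the extra heavy atom give no readable change at this aromatic carbon. Compound 4 is equally unresolved from the two longer groups, a number 5 percentage points higher from compound 2 to compound 4 (within the scatter) and a number 3 percentage points higher from compound 1 to compound 4 (within the scatter); it therefore lies within the scatter of all three earlier compounds, although cyano stands beyond the scatter of both longer groups, and the carbonyl alone cannot be read as what separates those groups from cyano. No measurement at hand bears on what lies behind these numbers.

Going by these compounds, whether a carboxylic acid, an aminomethyl group or a methyl ester on this aromatic carbon would give a number beyond the scatter of compound 3 remains open. On these data alone, all four numbers come from one tested concentration and describe only this position on the shared core, so potency and the effect of changing the rest of the structure also remain open.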